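The source may hold more compounds than are shown below. What is called first, only, known or untested is meant among the compounds shown, and "the series" means these compounds.

The measured compounds:

Compound 1, `CC(C)(C)Cn1cc2c(Cl)nc(NC(=O)c3ccccc3)nc2n1`, in an assay on CHO cells for displacement of a labelled ligand from adenosine receptor A3 (Homo sapiens), read by scintillation counting, with a stated time of 3 h (on this read-out higher numbers stand for weaker inhibition and lower numbers for stronger inhibition), compound 1 gives 30300 nM.
Compound 2, `CC(C)n1cc2c(Cl)nc(NC(=O)c3ccc(C(F)(F)F)cc3)nc2n1`, in this assay compound 2 gives 10300 nM.
Compound 3, `CC(C)n1cc2c(Cl)nc(NC(=O)c3ccc(F)cc3)nc2n1`, in this assay compound 3 gives > 60000 nM, which is a limit of the assay and not a number.

Compound 3 therefore stands at the weak end of everything shown, sitting at the limit of > 60000 nM in this assay, at which 1 of the 3 values shown sits. Among the compounds with values here, the one measured step that bears on the amide aryl group is an at least 5.8-fold higher number from compound 2 to compound 3 (0.76 log units; beyond the scatter), so within the measured set a change on that ring has moved the number markedly and, in that case, toward weaker binding.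

The next compound is compound 4, `CC(C)n1cc2c(Cl)nc(NC(=O)c3ccccc3)nc2n1`. It differs from compound 3 by hydrogen in place of fluoro on an aromatic carbon. Within the data shown here, compound 1 carries the same unsubstituted phenyl amide on a differently alkylated core and gives a number rather than a limit, 30300 nM; no single-change step connects it to compound 4, so its value is only a hint.

The expectation is that compound 4 will return to a measurable number, estimated at 40000 nM, within 15000 nM to 120000 nM. That estimate implies the step of an at least 1.5-fold lower number from compound 3 to compound 4 (0.17 log units; that floor lies within the scatter), expected to be toward stronger inhibition but with real chance that compound 4 also stays at the limit.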

Compound 4, inhibition constant: 12800 nM
Estimate against measurement, compound 4: 3.1-fold (0.49 log units) above; measured number outside the range, below it.
By their numbers in this assay, from the lowest: compounds 2 and 4 (each within the scatter of the next); then compound 1. At a limit, above all of these: compound 3.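

In this assay, the change from 4-fluorophenyl to phenyl, on an aromatic carbon para to a large group, gives an at least 4.6-fold lower number from compound 3 to compound 4 (0.67 log units; beyond the scatter), while replacing trifluoromethyl at that same place with hydrogen gives a 1.2-fold higher number from compound 2 to compound 4 (0.09 log units; within the scatter), so the earlier drop now reads as a loss tied to fluoro and not as a gain tied to trifluoromethyl. The size of the fluoro step is only a floor, because compound 3 stands at a limit and not at a number: the limit of > 60000 nM in this assay, at which 1 of the 4 values shown sits. Within the data shown here, compound 4 also opens the first single-change reading at the ring nitrogen, where isopropyl in place of neopentyl gives a 2.4-fold lower number from compound 1 to compound 4 (0.37 log units; beyond the scatter), a modest move toward stronger inhibition.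

What remains open is whether the fluoro result is peculiar to fluoro among small groups, since the compounds shown do not tell how a chloro, a methyl or a methoxy group would behave at that place on the ring. Going by these compounds, it is equally open how an ethyl or a cyclopentyl group on the ring nitrogen would compare with isopropyl.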